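The source may report more compounds than this note shows. Statements on the series, on what has been measured and on what is new or still open speak of the compounds shown alone.

Working notes on the series. All compounds share the core of compound 1 `CC(C)c1cccc(C(C)C)c1NC(=O)NCC1(c2ccc(CC(C)(C)C)cc2)CCCC1`; the variable part is the substituted phenyl on the saturated ring carbon. In an assay on microsomes for inhibition of acyl-CoA:cholesterol acyltransferase (Oryctolagus cuniculus) (a lower number here means a stronger inhibitor, a higher number a weaker inhibitor), compound 1 gives 159 nM. Compound 2 `CC(C)c1cccc(C(C)C)c1NC(=O)NCC1(c2ccc(Cl)cc2)CCCC1` gives 32 nM, and compound 3 `CC(C)c1cccc(C(C)C)c1NC(=O)NCC1(c2ccccc2C(F)(F)F)CCCC1` gives 18 nM. Compound 2 thus stands second among the three numbers: the step of a 5.0-fold lower number from compound 1 to compound 2 (0.70 log units; beyond the scatter) lies beyond the scatter, whereas compound 2 and compound 3 sit within the scatter of each other, as a 1.8-fold lower number from compound 2 to compound 3 (0.25 log units; within the scatter) shows. The step of an 8.8-fold lower number from compound 1 to compound 3 (0.95 log units; beyond the scatter) is also beyond the scatter.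

Compound 4 `CC(C)c1cccc(C(C)C)c1NC(=O)NCC1(c2ccc(NCCO)cc2)CCCC1` is not yet measured. It differs from compound 2 by (2-hydroxyethyl)amino in place of chloro on an aromatic carbon. Among the measured compounds shown here, the only measured step at this aromatic carbon, a 5.0-fold lower number from compound 1 to compound 2 (0.70 log units; beyond the scatter), exchanges neopentyl for chloro and so bears only loosely on the present change; no measured pair brings in a (2-hydroxyethyl)amino group anywhere. The direction is therefore open. For compound 4 the expected step in this assay is estimated as a 3.1-fold higher number from compound 2 to compound 4 (0.49 log units; beyond the scatter), with wide uncertainty. Compound 4 is estimated at 100 nM, in the range 25 nM to 400 nM.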

Compound 4, half-maximal inhibitory concentration: 25 nM
Compound 4: the middle estimate sits 4.0-fold (0.60 log units) above what was measured; low and high end bracket the measured number.
By their numbers in this assay, from the lowest: compounds 3, 4 and 2 (each within the scatter of the next); then compound 1.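

In this assay the aromatic carbon accepts (2-hydroxyethyl)amino as well as it accepts chloro: a 1.3-fold lower number from compound 2 to compound 4 (0.11 log units; within the scatter) shows that a larger group carrying hydrogen-bond donors and acceptors, which chloro lacks, leaves the number within the scatter. Neopentyl is now set apart from two different groups at this carbon, since a 6.4-fold lower number from compound 1 to compound 4 (0.80 log units; beyond the scatter) lies beyond the scatter, while a 1.4-fold higher number from compound 3 to compound 4 (0.14 log units; within the scatter) also stays within it. No measurement at hand bears on the reason for this tolerance.

As far as these compounds go, whether it extends to a simple dimethylamino group, a carboxylic acid or a longer hydroxyalkyl chain at this carbon stays open. Equally open, from the compounds shown here alone, is whether a small alkyl group such as ethyl would fall with chloro or with neopentyl.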